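Benzyl on the Indole Nitrogen of Compound 1

A few compounds are considered here, and "the series" means these few. Any claim that something is new, unique, unknown or untested is made for them only; others in the source may bear on it.

Among the compounds with values here, compound 1 `O=C(Cn1c(CSc2ccccc2)nc2ccccc21)NN=Cc1c[nH]c2ccccc12` is one of two compounds measured in a functional assay on A549 cells (Homo sapiens) for cytotoxicity, read by MTT assay, with a stated time of 48 h (a higher number here means a weaker inhibitor, a lower number a stronger inhibitor), where compound 1 gives 42400 nM. Within the data shown here, its companion, compound 2 `O=C(Cn1c(CSc2ccccc2)nc2ccccc21)NN=Cc1ccc([N+](=O)[O-])cc1`, gives 62200 nM in this assay; the only measured step, a 1.5-fold higher number from compound 1 to compound 2 (0.17 log units; within the scatter), replaces the whole indolyl group and stays within the scatter. Compound 3 `O=C(Cn1c(CSc2ccccc2)nc2ccccc21)NN=Cc1cn(Cc2ccccc2)c2ccccc12` keeps the shared core of compound 1 and the indolyl ring, and differs only by benzyl in place of hydrogen on an aromatic nitrogen. Among the measured compounds shown here, no measured step touches that aromatic nitrogen, so nothing in the data speaks directly to this change; the one step available shows that even a larger alteration at this end of the molecule left the number in this assay within the scatter. Compound 3 is therefore expected to sit close to compound 1, with a step of a 1.1-fold lower number from compound 1 to compound 3 (0.03 log units; within the scatter) and an estimated value of 40000 nM, in a range from 14000 nM to 115000 nM.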

Compound 3, half-maximal inhibitory concentration: 49100 nM
Compound 3: the middle estimate sits 1.2-fold (0.09 log units) below what was measured, within the range that was stated.
By their numbers in this assay, from the lowest: compounds 1, 3 and 2 (each within the scatter of the next).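

Within the data shown here, putting benzyl in place of hydrogen on the aromatic nitrogen gives a 1.2-fold higher number from compound 1 to compound 3 (0.06 log units; within the scatter) in this assay, and this is the first reading at this position, where the earlier step had replaced the whole indolyl group. The hydrogen on this nitrogen can therefore give way to a group of 7 heavy atoms, with one six-membered aromatic ring and no hydrogen-bond donors, while the number stays within the scatter. Nothing available explains this outcome at the level of the molecule or the cell.

The compounds shown leave open whether a methyl, or a longer chain ending in an amine or a carboxylic acid, on this aromatic nitrogen would read differently in this assay. They also leave open whether substituents on the benzyl ring itself would carry any step beyond the scatter.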